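Exchanging the Aryl Group While the Nitro Group Stays

The source may hold more compounds than are shown below. What is called first, only, known or untested is meant among the compounds shown, and "the series" means these compounds.

In a functional assay on HepG2 cells (Homo sapiens) for antiproliferative activity, read by MTT assay (a higher number here means a weaker inhibitor, a lower number a stronger inhibitor), compound 1 `COc1ccc(-c2ccnc(Nc3ccc([N+](=O)[O-])cc3)n2)cc1` gives 1040 nM as the lowest of three numbers. Compound 3 `COc1ccc(-c2ccnc(Nc3ccc(Cl)cc3)n2)cc1` gives 4500 nM and compound 2 `COc1ccc(-c2ccnc(Nc3cccc(OC)c3)n2)cc1` gives 13900 nM on the same cells. Compound 4 `O=[N+]([O-])c1ccc(Nc2nccc(-c3ccc(Cl)cc3Cl)n2)cc1` carries 2,4-dichlorophenyl in place of 4-methoxyphenyl on an aromatic carbon and keeps the nitro group of compound 1. Among the measured compounds shown here, the only measured step between compounds differing in one place is a 4.3-fold higher number from compound 1 to compound 3 (0.64 log units; beyond the scatter) and is modest. For the measured compounds named here, that step changes a different place, so no measured step covers this exchange. With no direction given by the data, no change beyond the scatter is expected in this assay and the estimated step is a 1.3-fold higher number from compound 1 to compound 4 (0.10 log units; within the scatter) at this stage. For compound 4 the estimated value is 1300 nM (expected range 300 nM to 5500 nM).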

Compound 4, half-maximal inhibitory concentration: 99300 nM
Beside the measured number, compound 4's estimate is 76-fold (1.88 log units) below it, outside the stated range (above it).
By their numbers in this assay, from the lowest: compound 1; then compound 3; then compound 2; then compound 4.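

Among the compounds shown here, the earlier compounds varied only the other aryl group, so this is the first reading at this position, and it is far from silent. In this assay, exchanging 4-methoxyphenyl for 2,4-dichlorophenyl gives a 95-fold higher number from compound 1 to compound 4 (1.98 log units; beyond the scatter), which exceeds the modest 4.3-fold higher number from compound 1 to compound 3 (0.64 log units; beyond the scatter) at the nitro group. No measurement shown here accounts for this loss of activity. On these data alone, it remains open whether removing the methoxy group or adding the two chlorines carries the step. As far as these compounds go, what an amine or a hydroxyl group would give at this position also remains open.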